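Bromo in place of methoxy: expecting little change

The source may hold more compounds than are shown below. What is called first, only, known or untested is meant among the compounds shown, and "the series" means these compounds.

Measured so far in an assay on HEK-293T cells for displacement of a labelled ligand from corticotropin-releasing factor receptor 2 (Homo sapiens), read by scintillation counting, with a stated time of 2 h, tested at 1 uM; a higher number here means more inhibition at the concentration tested (going by the name of the read-out), a lower number less inhibition:
compound 1 `CCCCN(CC)c1cc(C)nc2c1NC(=O)CN2c1ccc(C)cc1Cl`: "not determined" (no result reported)
compound 2 `CCCCN(CC)c1cc(C)nc2c1NC(=O)CN2c1ccc(C)cc1Br`: 5.5%
compound 3 `CCCCN(CC)c1cc(C)nc2c1NC(=O)CN2c1ccc(OC)cc1C`: -2.3%

Compound 3 gives the lowest of the two numbers, yet the step of a number 7.8 percentage points lower from compound 2 to compound 3 (within the scatter) lies within the scatter, so no order between these two compounds can be read. Compound 4 `CCCCN(CC)c1cc(C)nc2c1NC(=O)CN2c1ccc(Br)cc1C` differs from compound 3 by bromo in place of methoxy on an aromatic carbon. Within the data shown here, only one measured step touches this ring, and it stayed within the scatter, while both measured values sit near zero inhibition. Compound 4 is therefore expected to show no step beyond the scatter, a number 5.3 percentage points higher from compound 3 to compound 4 (within the scatter). Compound 4 is estimated to give 3% in this assay, with an expected range from -9% to 15%.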

Compound 4, a percentage reported as inhibition, at one concentration (the size of the read-out at that concentration, not a potency): 5.9%
For compound 4 the middle estimate is 2.9 percentage points below the measured one; low and high end bracket the measured number.
By their numbers in this assay, from the lowest: compounds 3, 2 and 4 (each within the scatter of the next).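

In this assay, bromo in place of methoxy on this aromatic carbon gives a number 8.2 percentage points higher from compound 3 to compound 4 (within the scatter), so this single-group exchange has no readable effect. The change from 2-bromo-4-methylphenyl to 4-bromo-2-methylphenyl gives a number 0.4 percentage points higher from compound 2 to compound 4 (within the scatter), so exchanging the bromo and methyl places on the ring cannot be read as a change either. No measurement on hand offers an explanation for these results.

Going by these compounds, whether an amine or a carboxylic acid on this aromatic carbon would produce a step beyond the scatter stays open. So does whether any group here can lift inhibition clearly away from zero.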